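This account rests on a few compounds, and the source may have more. Where it says the series, first, only, none or still open, it means among the compounds named here.

Measured compounds in a functional assay on MDA-MB-231 cells (Homo sapiens) for antiproliferative activity, read by MTT assay, with stated times of 72 h and 4 h; a higher number here means a weaker inhibitor, a lower number a stronger inhibitor:
Compound 1 `O=C(Nc1ccc(Cl)c(-c2nnc3c(Cl)cccn23)c1)c1ccc(Cl)cc1` gives only a limit, > 100000 nM.
Compound 2 `O=C(Nc1ccc(Cl)c(-c2nnc3c(Cl)cccn23)c1)c1cccc(Cl)c1` gives 66100 nM.

Going by the values given here, compound 2 holds the only number in this assay. Compound 1 sits at the limit of > 100000 nM in this assay, at which 1 of the 2 values shown sits. Compound 3 `Cc1cc(Cl)ccc1C(=O)Nc1ccc(Cl)c(-c2nnc3c(Cl)cccn23)c1` differs from compound 2 by 4-chloro-2-methylphenyl in place of 3-chlorophenyl on a carbonyl carbon. Among the compounds with values here, the one measured step touching the ring on the carbonyl carbon is an at least 1.5-fold lower number from compound 1 to compound 2 (0.17 log units; that floor lies within the scatter), which does not rise beyond the scatter. A similarly small step, or none, is therefore expected for a 1.2-fold higher number from compound 2 to compound 3 (0.08 log units; within the scatter), with a real chance that this assay reports only a limit. Compound 3 is estimated at 80000 nM, range 30000 nM to 200000 nM.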

Compound 3, half-maximal inhibitory concentration: > 100000 nM
Compound 3: only a limit was reported; the forecaster's own chance of this, stated with the estimate: 40%; middle value at least 1.2-fold (0.09 log units) away from the limit.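

In this assay, 4-chloro-2-methylphenyl in place of 3-chlorophenyl on the carbonyl carbon gives an at least 1.5-fold higher number from compound 2 to compound 3 (0.17 log units; that floor lies within the scatter), so this change shows no gain in potency. The step between compound 1 and compound 3 cannot be read: both values are limits. No step at this position yet rises beyond the scatter, and the values gather at a single limit: the limit of > 100000 nM in this assay, at which 2 of the 3 values shown sit.

On these data alone, whether an amine or a carboxylic acid on this ring would give a clearly lower number than compound 2 stays open. So does the effect of a longer chain in place of the ring.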